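This account rests on a few compounds, and the source may have more. Where it says the series, first, only, none or still open, it means among the compounds named here.

Measured compounds in an ADME assay on microsomes from liver (Rattus norvegicus) for metabolic stability, with a stated time of 10 min; a lower number here means that less of the compound is left, a higher number that more of the compound is left:
- compound 1 `CC(C)(C)OC(=O)NCCS(=O)(=O)NC(=O)c1ccc(Nc2nc(NC3(c4ccc(Cl)cc4)CC3)nc(OCC(F)(F)F)n2)cc1` gives 93%
- compound 2 `COC(=O)NCCS(=O)(=O)NC(=O)c1ccc(Nc2nc(NC3(c4ccc(Cl)cc4)CC3)nc(OCC(F)(F)F)n2)cc1` gives 100%

Compound 2 holds the highest of the two numbers, and its nearest neighbour is compound 1, which differs by the step of a number 7 percentage points higher from compound 1 to compound 2 (within the scatter); that gap sits within the scatter, so the two cannot be ordered. The shared core of both compounds carries a sulfonyl-amide chain, and the only variation measured so far is on the oxygen of the carbamate.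

Compound 3 `CC(C)(C)CNCCS(=O)(=O)NC(=O)c1ccc(Nc2nc(NC3(c4ccc(Cl)cc4)CC3)nc(OCC(F)(F)F)n2)cc1` departs from compound 2 in a different way: neopentyl in place of methoxycarbonyl on an amine nitrogen. For the measured compounds named here, no measured step covers an exchange of this kind; the one step available, from compound 1 to compound 2, touches only the oxygen side of the carbamate and was itself within the scatter. It therefore offers no direction for this assay, and the expectation for compound 3 rests on the value of compound 2 alone, widened for the untested change. The estimate for compound 3 is 85%, within 60% to 100%. That corresponds to an expected step of a number 15 percentage points lower from compound 2 to compound 3 (beyond the scatter).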

Compound 3, percent of the compound remaining: 90%
Compound 3: middle estimate off by 5 percentage points, on the low side, and the stated range covers the measured number.
By their numbers in this assay, from the lowest: compounds 3, 1 and 2 (each within the scatter of the next).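

In this assay, for the compounds shown here, the earlier compounds varied only the oxygen side of the carbamate, whereas this result replaces the whole carbamate on the amine nitrogen. Neopentyl in place of methoxycarbonyl gives a number 10 percentage points lower from compound 2 to compound 3 (within the scatter), and neopentyl in place of tert-butoxycarbonyl gives a number 3 percentage points lower from compound 1 to compound 3 (within the scatter), so neither exchange can be read as a real change. At this position, then, a group of five carbons with no hydrogen-bond acceptors cannot be told apart in this read-out from either carbamate, although methoxycarbonyl brings two acceptors and a double bond, and nothing measured here offers an explanation for this.

The three compounds leave open whether any group on this nitrogen would move the number beyond the scatter, since all of them lie within the scatter of one another. As far as these compounds go, a free primary amine, an acetyl group, a carboxylic acid at the end of the chain or a longer chain carrying the amine could each answer that, and the effect of any of them in this assay remains unknown.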